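Chloro on the hydroxyphenyl ring of the diketone series

A few compounds are considered here, and "the series" means these few. Any claim that something is new, unique, unknown or untested is made for them only; others in the source may bear on it.

Compound 1 `Cc1ccc2oc(-c3cc4ccccc4s3)cc(=O)c2c1` and compound 2 `O=C(CC(=O)c1ccccc1O)c1cc2ccccc2s1` carry the same benzothiophene-bearing fragment on different scaffolds. In an ADME assay on HeLa cells (Homo sapiens) for inhibition, read by MTT assay, with a stated time of 72 h (on this read-out lower numbers stand for stronger inhibition of growth and higher numbers for weaker inhibition of growth), compound 1 gives 15.6 ug/mL. Compound 2 gives 7.86 ug/mL, a number that sits within the scatter of compound 1, so no order between the two can be claimed. Compound 3 `O=C(CC(=O)c1cc(Cl)ccc1O)c1cc2ccccc2s1` differs from compound 2 by chloro in place of hydrogen on an aromatic carbon. For the measured compounds named here, no measured pair shows what this change does here. The expectation is a step of a 1.3-fold lower number from compound 2 to compound 3 (0.12 log units; within the scatter) that stays within the scatter. Compound 3 is accordingly estimated at 6 ug/mL, with a range from 2.5 ug/mL to 15 ug/mL.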

Compound 3, concentration for 50% growth inhibition: 4.42 ug/mL
For compound 3 the middle estimate is 1.4-fold (0.13 log units) above the measured one, and the stated range covers the measured number.
By their numbers in this assay, from the lowest: compounds 3, 2 and 1 (each within the scatter of the next, the first and the last beyond it).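

In this assay, chloro in place of hydrogen on the aromatic carbon para to a hydroxy group gives a 1.8-fold lower number from compound 2 to compound 3 (0.25 log units; within the scatter) and so stays within the scatter. This position therefore tolerates chloro in this series, but no order between compound 2 and compound 3 can be claimed. Nothing available bears on the reason for this result.

Still open, as far as these compounds go, is how other groups at this position would read, such as an amine, a carboxylic acid or a methoxy group. Also open, from the compounds shown here alone, is whether chloro gives a similar step on the core of compound 1.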